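The source may report more compounds than this note shows. Statements on the series, on what has been measured and on what is new or still open speak of the compounds shown alone.

Series notes. In a functional assay on NCI-H1975 cells (Homo sapiens) for inhibition, read by MTT assay, with a stated time of 72 h (a higher number here means a weaker inhibitor, a lower number a stronger inhibitor), compound 1 `CCOc1cc2ncnc(Nc3ccc(F)c(Cl)c3)c2cc1OC(=O)CSc1cccnc1` gives 3000 nM. For the measured compounds named here, compound 2 `CCOc1cc2ncnc(Nc3ccc(F)c(Cl)c3)c2cc1OC(=O)CSc1nc2ccccc2s1` gives 9800 nM, the highest number of the two measured so far, reached by a 3.3-fold higher number from compound 1 to compound 2 (0.51 log units; beyond the scatter). Compound 3 `CCOc1cc2ncnc(Nc3ccc(F)c(Cl)c3)c2cc1OC(=O)CSc1nc2cc(OC)ccc2s1` is not yet measured; it differs from compound 2 by methoxy in place of hydrogen on an aromatic carbon. Going by the values given here, no measured step covers a change of this kind: the single measured step exchanges the whole ring system on the sulfur and says nothing about a substituent on that ring system. A step within the usual scatter is expected, a 1.0-fold higher number from compound 2 to compound 3 (0.01 log units; within the scatter). Compound 3 is accordingly estimated at 10000 nM, within 4000 nM to 25000 nM.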

Compound 3, half-maximal inhibitory concentration: 3200 nM
The estimate for compound 3 lay 3.1-fold (0.49 log units) above the measured number; the whole stated range lies above it.
By their numbers in this assay, from the lowest: compounds 1 and 3 (each within the scatter of the next); then compound 2.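

In this assay the fused ring system on the sulfur responds to substitution: methoxy in place of hydrogen on its aromatic carbon gives a step beyond the scatter (a 3.1-fold lower number from compound 2 to compound 3 (0.49 log units; beyond the scatter)). With this methoxy present, the 5-methoxy-1,3-benzothiazol-2-yl and pyridin-3-yl groups cannot be told apart (a 1.1-fold higher number from compound 1 to compound 3 (0.03 log units; within the scatter)). No evidence is available that accounts for this step.

Open, going by these compounds, is whether an amine, a fluorine or a longer ether such as ethoxy on the same carbon gives a similar step. Also open, on these data alone, is how methoxy behaves on the other aromatic carbons of this ring.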